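Cyano in place of trifluoromethyl: compound 3 to compound 4

The compounds below may be only part of what the source reports. "The series", "measured", "known", "first", "only" and "open" are said of these compounds alone.

Measured so far in an ADME assay on L02 cells (Homo sapiens) for cytotoxicity, read by MTT assay, with a stated time of 24 h; a higher number here means a weaker inhibitor, a lower number a stronger inhibitor:

Compound 1 `COc1ccc(/C=C2\CN(C)C/C(=C\c3ccccc3F)C2=O)cc1` gives 22100 nM
Compound 2 `CN1C/C(=C\c2ccc(C(C)(C)C)cc2)C(=O)/C(=C/c2ccccc2F)C1` gives 25800 nM
Compound 3 `CN1C/C(=C\c2ccc(C(F)(F)F)cc2)C(=O)/C(=C/c2ccccc2F)C1` gives 18600 nM

Compound 3 cannot be separated from the other two compounds on these numbers. The comparison shows a 1.2-fold lower number from compound 1 to compound 3 (0.07 log units; within the scatter) and also a 1.4-fold lower number from compound 2 to compound 3 (0.14 log units; within the scatter), so its place among the three carries little weight.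

The next compound is compound 4 (`CN1C/C(=C\c2ccc(C#N)cc2)C(=O)/C(=C/c2ccccc2F)C1`), which has cyano in place of trifluoromethyl on an aromatic carbon, para to a large group (cyano in place of trifluoromethyl on an aromatic carbon). The rest of the structure stays as in compound 3.

Three measured steps exchange a group at this same aromatic carbon. Besides the two above, there is a 1.2-fold higher number from compound 1 to compound 2 (0.07 log units; within the scatter). Methoxy, tert-butyl and trifluoromethyl thus give values within the scatter of one another, although cyano itself has not been measured on this core. Because a 1.4-fold lower number from compound 2 to compound 3 (0.14 log units; within the scatter) is the widest of these steps, no larger change is expected here. The step expected is a 1.1-fold higher number from compound 3 to compound 4 (0.03 log units; within the scatter), and no move beyond the scatter is expected in either direction in this assay. Compound 4 is therefore estimated at 20000 nM (expected range 11000 nM to 34000 nM).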

Compound 4, half-maximal inhibitory concentration: 11000 nM
For compound 4 the middle estimate is 1.8-fold (0.26 log units) above the measured one; low and high end bracket the measured number.
By their numbers in this assay, from the lowest: compounds 4, 3, 1 and 2 (each within the scatter of the next, the first and the last beyond it).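

In this assay, the exchange of groups at this aromatic carbon produces its first step beyond the scatter, a 2.3-fold lower number from compound 2 to compound 4 (0.37 log units; beyond the scatter), and this step is modest; none of the earlier exchanges among methoxy, tert-butyl and trifluoromethyl went that far. The result rests on that single pair, however, since the other two steps to the cyano compound, a 1.7-fold lower number from compound 3 to compound 4 (0.23 log units; within the scatter) and a 2.0-fold lower number from compound 1 to compound 4 (0.30 log units; within the scatter), both stay within the scatter, so cyano is separated only from tert-butyl and the direct exchange for trifluoromethyl cannot be read as a real change. Nothing available here accounts for the separation from tert-butyl.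

The compounds shown leave open whether a primary amine or a carboxylic acid at this same aromatic carbon would move the number further from those of the four groups seen so far. They also leave open whether the gap between cyano and tert-butyl would persist if the rest of the shared core were changed, as all four compounds keep it constant.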